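The compounds below may be only part of what the source reports. "The series", "measured", "known", "first", "only" and "open" are said of these compounds alone.

Three compounds share one core and differ only in the ring attached to the outer amide-type nitrogen. Compound 1 `Cc1cccc(NC(=O)Nc2nnc(Sc3ncnc4scc(-c5ccncc5)c34)s2)c1` carries a 3-methylphenyl group there, and in a functional assay on HUVEC cells (Homo sapiens) for antiproliferative activity, read by MTT assay, with a stated time of 48 h (a higher number here means a weaker inhibitor, a lower number a stronger inhibitor), compound 1 gives 12200 nM. Compound 2 `COc1ccc(NC(=O)Nc2nnc(Sc3ncnc4scc(-c5ccncc5)c34)s2)cc1` carries a 4-methoxyphenyl group, and in this assay compound 2 gives 16900 nM. Compound 3 `Cc1ccc(NC(=O)Nc2nnc(Sc3ncnc4scc(-c5ccncc5)c34)s2)cc1` carries a 4-methylphenyl group, and in this assay compound 3 gives 19300 nM. On these numbers compound 3 has the highest of the three, but every difference among them is within the scatter: a 1.6-fold higher number from compound 1 to compound 3 (0.20 log units; within the scatter), a 1.4-fold higher number from compound 1 to compound 2 (0.14 log units; within the scatter) and a 1.1-fold higher number from compound 2 to compound 3 (0.06 log units; within the scatter).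

Compound 4 `O=C(Nc1ccc(Cl)c(Cl)c1)Nc1nnc(Sc2ncnc3scc(-c4ccncc4)c23)s1` is the next member, not yet measured. The change from compound 3 reads: 3,4-dichlorophenyl in place of 4-methylphenyl on an amide-type nitrogen. All three measured steps bear on it in the sense that they also swap groups on this ring, and all three were small. Yet none of them introduces a chlorine, and no measured compound holds a halogen, so the effect of two chlorines is not shown anywhere. Based only on the small steps seen, the step from compound 3 to compound 4 in this assay is expected to be a 1.3-fold lower number from compound 3 to compound 4 (0.11 log units; within the scatter). Compound 4 is therefore expected to give about 15000 nM in this assay, with a range from 5000 nM to 45000 nM.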

Compound 4, half-maximal inhibitory concentration: 7800 nM
Compound 4: middle estimate off by 1.9-fold (0.28 log units), on the high side, and the stated range covers the measured number.
By their numbers in this assay, from the lowest: compounds 4, 1, 2 and 3 (each within the scatter of the next, the first and the last beyond it).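

Among the steps on this ring, only those that bring in 3,4-dichlorophenyl on the amide-type nitrogen go beyond the scatter in this assay: replacing 4-methylphenyl gives a 2.5-fold lower number from compound 3 to compound 4 (0.39 log units; beyond the scatter) and replacing 4-methoxyphenyl gives a 2.2-fold lower number from compound 2 to compound 4 (0.34 log units; beyond the scatter) for the same core. The ring can therefore shift the number measurably, although the separation is modest and does not hold against every neighbour, since replacing 3-methylphenyl gives only a 1.6-fold lower number from compound 1 to compound 4 (0.19 log units; within the scatter) and compound 1 thus goes against any claim that this group beats all the others. No measurement shown here gives a reason for these shifts at this position.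

With both chlorines entering together, the compounds shown cannot tell whether a single chlorine on this ring would give the same step or whether the pair is needed. Also open, from the compounds shown here alone, is how quite different groups on this ring would behave, such as a fluorine, a trifluoromethyl, an amine or a carboxylic acid, or a longer chain in place of the ring, and whether any of them would move the number further than the modest steps seen here.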